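The compounds below may be only part of what the source reports. "The series", "measured", "known", "first", "only" and "open" are said of these compounds alone.

Measured compounds in a physicochemical assay for solubility, in phosphate buffer, measured as kinetic solubility; on this read-out lower numbers stand for lower solubility and higher numbers for higher solubility:
- compound 1 `CC(C)C(c1ccc(-c2ccc3cccc(F)c3c2)[nH]c1=O)C1C(=O)NC(=O)N1C` gives 17900 nM
- compound 2 `CCC(/C=C1\OC(=O)NC1=O)(CC)c1ccc(-c2ccc3cccc(F)c3c2)[nH]c1=O` gives 32600 nM
- compound 3 `O=C1NC(=O)/C(=C/C(Cc2ccccc2)c2ccc(-c3ccc4cccc(F)c4c3)[nH]c2=O)O1` gives 9100 nM

Compound 1 stands second highest of the three numbers in this assay. Its nearest neighbour is compound 2, whose value is higher but within the usual scatter; the furthest is compound 3, whose value is lower, again within the scatter. The three measured values therefore do not separate cleanly from one another.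

The next compound in the series, compound 4 `CC(C)C(CC1C(=O)NC(=O)N1C)c1ccc(-c2ccc3cccc(F)c3c2)[nH]c1=O`, differs from compound 1 in one place: (3-methyl-2,5-dioxoimidazolidin-4-yl)methyl in place of 3-methyl-2,5-dioxoimidazolidin-4-yl on a saturated chain carbon bound to an aromatic carbon and a saturated chain carbon. The shared core is untouched, and the change adds a single saturated chain carbon between the side chain and the ring of the substituent.

Among the measured compounds shown here, no direct step between two measured compounds is available for this kind of change, so the expectation rests on compound 1 alone, whose value is 17900 nM. A step of this size is expected to stay within the scatter, if anything slightly downward. For compound 4 the estimate in this assay is 14000 nM, with a range from 6000 nM to 35000 nM, which corresponds to an expected step of a 1.3-fold lower number from compound 1 to compound 4 (0.11 log units; within the scatter).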

Compound 4, solubility: 33600 nM
Estimate against measurement, compound 4: 2.4-fold (0.38 log units) below; measured number inside the range.
By their numbers in this assay, from the lowest: compounds 3, 1, 2 and 4 (each within the scatter of the next, the first and the last beyond it).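

In this assay, the series now has its first comparison of compounds that differ in one place: a 1.9-fold higher number from compound 1 to compound 4 (0.27 log units; within the scatter). At this position, on a saturated chain carbon bound to an aromatic carbon and a saturated chain carbon, (3-methyl-2,5-dioxoimidazolidin-4-yl)methyl in place of 3-methyl-2,5-dioxoimidazolidin-4-yl gives no difference that separates from the scatter. No measured property bears on this step, so it carries no assignable cause.

On these data alone, it remains open whether a longer chain linking the same ring, or an amine or a carboxylic acid in place of that ring, would give a step beyond the scatter. A single step also leaves open whether this change would read the same with a different group on that saturated chain carbon.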